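Working notes: dichlorophenyl replacement in the series

A few compounds are considered here, and "the series" means these few. Any claim that something is new, unique, unknown or untested is made for them only; others in the source may bear on it.

Compound 1 `O=C1NC(=O)/C(=C\c2ccc(OCC(=O)N3N=C(c4ccccc4)CC3c3ccc(C(F)(F)F)cc3)cc2)S1` is the reference point; in an assay on cells for inhibition of histone deacetylase 8 (Homo sapiens), read by fluorescence, with a stated time of 30 min (on this read-out higher numbers stand for weaker inhibition and lower numbers for stronger inhibition), compound 1 gives 16000 nM. Compound 2 `O=C1NC(=O)/C(=C\c2ccc(OCC(=O)N3N=C(c4ccc(F)cc4)CC3c3ccc(C(F)(F)F)cc3)cc2)S1` carries fluoro in place of hydrogen on an aromatic carbon. In this assay compound 2 reaches > 50000 nM, which is a limit of the assay and not a number. The step of an at least 3.1-fold higher number from compound 1 to compound 2 (0.49 log units; beyond the scatter) therefore reads as a weakening whose size is open at the upper end (the limit of > 50000 nM in this assay, at which 1 of the 2 values shown sits). Compound 2 thus stands at the weak end of what has been measured so far.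

Compound 3 `O=C1NC(=O)/C(=C\c2ccc(OCC(=O)N3N=C(c4ccc(F)cc4)CC3c3ccc(Cl)c(Cl)c3)cc2)S1` differs from compound 2 by 3,4-dichlorophenyl in place of 4-(trifluoromethyl)phenyl on a saturated ring carbon. No measured step touches that position; the only step shown, from compound 1 to compound 2, concerns the other aryl group and gives no guide to direction here. Starting from a limit, the expectation for compound 3 in this assay is a number in the same region, with a fair chance that only a limit is reported again; the step of a number no higher from compound 2 to compound 3 (the limit leaves the size open) is expected to stay within the scatter. Compound 3 is estimated at 50000 nM, between 15000 nM and 160000 nM.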

Compound 3, half-maximal inhibitory concentration: 25000 nM
Beside the measured number, compound 3's estimate is 2.0-fold (0.30 log units) above it, and the stated range covers the measured number.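

In this assay, going by these compounds alone, 3,4-dichlorophenyl in place of 4-(trifluoromethyl)phenyl on the saturated ring carbon returns a readable number, with compound 3 at 25000 nM, so this is the first measured change at this position and the first evidence that it can move the read-out bearing the 4-fluorophenyl group. The step reads as an at least 2.0-fold lower number from compound 2 to compound 3 (0.30 log units; that floor lies within the scatter), so the printed floor alone does not establish a real strengthening, although the true size may be larger. The value of compound 2 is a limit of the assay and not a number, which leaves the size of the step open: the limit of > 50000 nM in this assay, at which 1 of the 3 values shown sits.

Going by these compounds, it remains open whether a 4-chlorophenyl group, a 3-chlorophenyl group or a carboxylic acid on the same saturated ring carbon would give a number that separates from compound 3 beyond the scatter. Also open, on these data alone, is whether 3,4-dichlorophenyl would have a similar effect alongside the unsubstituted phenyl group of compound 1, where a true number, rather than a limit, would serve as the starting point.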